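Mirror-image partner of the highest compound in the series

This account rests on a few compounds, and the source may have more. Where it says the series, first, only, none or still open, it means among the compounds named here.

Measured in a physicochemical assay for lipophilicity, measured as octanol-water partition, at pH 7.4; a higher number here means a more lipophilic compound, a lower number a more polar compound:
Compound 1 `Cc1ccc2[nH]c(C(=O)N[C@H]3CN(S(=O)(=O)c4ccccc4)C[C@@H]3C(=O)NCCN(C)C)cc2c1`: 2.1
Compound 2 `Cc1ccc2[nH]c(C(=O)N[C@H]3CN(S(=O)(=O)c4cccnc4)C[C@@H]3C(=O)NCCN(C)C)cc2c1`: 1.4
Compound 3 `Cc1ccc2[nH]c(C(=O)N[C@H]3CN(S(=O)(=O)c4cn(C)nc4C)C[C@@H]3C(=O)NCCN(C)C)cc2c1`: 1.4

Compound 1 stands highest of the three in this assay, and its steps to the other two lie beyond the scatter. These are a number 0.70 log units lower from compound 1 to compound 2 (beyond the scatter) and a number 0.70 log units lower from compound 1 to compound 3 (beyond the scatter). The remaining pair shows no change at the digits printed from compound 2 to compound 3 (within the scatter).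

Compound 4 `Cc1ccc2[nH]c(C(=O)N[C@@H]3CN(S(=O)(=O)c4ccccc4)C[C@H]3C(=O)NCCN(C)C)cc2c1` has not yet been measured. Its relation to compound 1 is simple: the two compounds have the same atoms and bonds and differ only in configuration as drawn: 2 of 2 stereo elements differ (all stereocentres are inverted: mirror images); a stereocentre at a saturated ring carbon is drawn R in compound 1 and S in compound 4; a stereocentre at a saturated ring carbon is drawn S in compound 1 and R in compound 4. The measured steps bear on it only indirectly. All of them replace the group on the sulfonyl sulfur, and none tests a change of configuration. Their size therefore offers no guide here. With the same atoms and bonds in both mirror images, no step beyond the scatter is expected, and the expectation is anchored on compound 1 at 2.1. For compound 4, the estimated outcome is no change at the digits printed from compound 1 to compound 4 (within the scatter). Compound 4 is expected to give 2.1, within an estimated range of 1.8 to 2.4.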

Compound 4, distribution coefficient: 2.1
The estimate for compound 4 equals the measured number at the digits printed; the measured number falls inside the stated range.
By their numbers in this assay, from the lowest: compounds 2 and 3 (each within the scatter of the next); then compounds 1 and 4 (each within the scatter of the next).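

In this assay, among these compounds, the new pair gives no change at the digits printed from compound 1 to compound 4 (within the scatter), the first comparison to test configuration rather than the group on the sulfonyl sulfur. At these two saturated ring carbons, inverting both stereocentres therefore leaves the read-out level, whereas replacing phenyl on the sulfonyl sulfur gave a number 0.70 log units lower from compound 1 to compound 2 (beyond the scatter) and a number 0.70 log units lower from compound 1 to compound 3 (beyond the scatter). The level result is what this pair should give, because nothing but the drawn stereochemistry separates the two structures: the fact that compounds 1 and 4 differ only in the configuration as drawn

The compounds shown leave open how this read-out responds when only one of the two stereocentres is inverted, which would give a partner of compound 1 that is not its mirror image. They also leave open what happens away from the sulfonyl sulfur, for example with a carboxylic acid in place of the dimethylamino group.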